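The source may hold more compounds than are shown below. What is called first, only, known or untested is meant among the compounds shown, and "the series" means these compounds.

Measured so far:
compound 1, `Cc1cc(-c2nc3cc(Cl)ccc3o2)ccc1NC(=O)CN1CCN(CCCN(C)C)CC1`, gives 9150 nM in a functional assay on HT-29 cells (Homo sapiens) for cytotoxicity, read by MTT assay, with a stated time of 24 h; a lower number here means a stronger inhibitor, a higher number a weaker inhibitor;
compound 2, `Cc1cc(-c2nc3ccccc3o2)ccc1NC(=O)CN1CCN(CCCN(C)C)CC1`, gives 15500 nM in this assay;
compound 3, `CN(C)CCCN1CCN(CC(=O)Nc2ccc(-c3nc4ccccc4o3)cc2)CC1`, gives 10600 nM in this assay.

Compound 2 and compound 1 differ in a single place: chloro in place of hydrogen on an aromatic carbon. That change made a 1.7-fold lower number from compound 2 to compound 1 (0.23 log units; within the scatter). The cores of compound 3 and compound 2 differ in another way: hydrogen in place of methyl on an aromatic carbon, with a 1.5-fold lower number from compound 2 to compound 3 (0.17 log units; within the scatter). Compound 4, `CN(C)CCCN1CCN(CC(=O)Nc2ccc(-c3nc4cc(Cl)ccc4o3)cc2)CC1`, has not yet been measured; it stands to compound 3 as compound 1 stands to compound 2, namely (chloro in place of hydrogen on an aromatic carbon), at the same place on the fused ring, so it is the same change. Among the measured compounds shown here, a step of about the earlier size is expected, a 1.6-fold lower number from compound 3 to compound 4 (0.21 log units; within the scatter), because a 1.7-fold lower number from compound 2 to compound 1 (0.23 log units; within the scatter) is the only reading of this change available and it lay within the scatter. Compound 4 is therefore estimated at 6500 nM, with 3000 nM to 14000 nM as the likely range.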

Compound 4, half-maximal inhibitory concentration: 1640 nM
Compound 4: middle estimate off by 4.0-fold (0.60 log units), on the high side; measured number below the stated range.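

The chloro group does not carry over from one core to the other at a fixed size: on the core without the methyl it gives a 6.5-fold lower number from compound 3 to compound 4 (0.81 log units; beyond the scatter), well beyond what it gave on the methyl core: the same change on two cores in this assay, a 1.7-fold lower number (0.23 log units; within the scatter) from compound 2 to compound 1 and a 6.5-fold lower number (0.81 log units; beyond the scatter) from compound 3 to compound 4, 3.8-fold (0.58 log units) apart, beyond the scatter of two such steps

The same holds when the methyl is the change read, with a 5.6-fold lower number from compound 1 to compound 4 (0.75 log units; beyond the scatter) once the chloro is present: the same change on two cores in this assay, a 1.5-fold lower number (0.17 log units; within the scatter) from compound 2 to compound 3 and a 5.6-fold lower number (0.75 log units; beyond the scatter) from compound 1 to compound 4, 3.8-fold (0.58 log units) apart, beyond the scatter of two such steps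

So in this series, a step read on one core cannot simply be added to another, though each reading rests on a single pair of compounds, and these numbers do not show why the two cores differ.

Going by these compounds, whether a fluoro or methoxy group in place of the chloro would also depend on the core stays open. So does whether an ethyl group in place of the methyl would behave as the methyl does.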